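Series notes: shortening the piperidine acyl chain to a methylurea

The source may hold more compounds than are shown below. What is called first, only, known or untested is meant among the compounds shown, and "the series" means these compounds.

Compound 2 `Cc1ccccc1C(=O)Nc1ccc(S(=O)(=O)NC2CCN(C(=O)CCCCN)CC2)c2ccccc12` stands highest of the two numbers measured in an assay on L1.2 cells for binding affinity to C-C chemokine receptor type 8 (Homo sapiens) (on this read-out lower numbers stand for stronger inhibition and higher numbers for weaker inhibition), giving 199 nM. For the measured compounds named here, its nearest neighbour, compound 1 `Cc1ccccc1C(=O)Nc1ccc(S(=O)(=O)NC2CCN(C(=O)CCCN)CC2)c2ccccc12`, gives 1.6 nM in this assay, and the only step between measured compounds, a 120-fold higher number from compound 1 to compound 2 (2.09 log units; beyond the scatter), is a large loss for moving the amino group one carbon further out. Compound 3 `CNC(=O)N1CCC(NS(=O)(=O)c2ccc(NC(=O)c3ccccc3C)c3ccccc23)CC1` is not yet measured; it differs from compound 2 by methylamino in place of 4-aminobutyl on a carbonyl carbon. Going by the values given here, no measured step covers removal of the amino chain itself, so the one step on record bears only indirectly: it shows the read-out is highly sensitive to what hangs from this carbonyl. With the amino group gone altogether, a weak result is expected for compound 3, estimated at 300 nM with a range of 30 nM to 3000 nM, meaning an expected step of a 1.5-fold higher number from compound 2 to compound 3 (0.18 log units; within the scatter) that may not exceed the scatter.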

Compound 3, inhibition constant: 0.7 nM
For compound 3 the middle estimate is 430-fold (2.63 log units) above the measured one; measured number outside the range, below it.
By their numbers in this assay, from the lowest: compound 3; then compound 1; then compound 2.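

In this assay, methylamino in place of 4-aminobutyl on the carbonyl carbon gives a 280-fold lower number from compound 2 to compound 3 (2.45 log units; beyond the scatter) and so more than recovers the loss seen on lengthening the chain. Methylamino in place of 3-aminopropyl gives a 2.3-fold lower number from compound 1 to compound 3 (0.36 log units; beyond the scatter) and makes compound 3 the strongest of the three, so a chain amino group is not required for a low number at this position, and a long acyl chain is not the only route to one. Nothing measured here accounts for these differences.

The compounds shown leave open how far the methyl group itself matters, which an unsubstituted amino, ethylamino or dimethylamino group on the same carbonyl carbon would test. They also leave open how a shorter 2-aminoethyl chain or a chain ending in a carboxylic acid would read.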